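A few compounds are considered here, and "the series" means these few. Any claim that something is new, unique, unknown or untested is made for them only; others in the source may bear on it.

Compound 1 `O=c1[nH]c(=O)n([C@@H]2O[C@@H]3COP(=O)(O)O[C@H]3[C@H]2O)cc1I` gives 359 ug/mL in a functional assay on Raji cells (Homo sapiens); a higher number here means a weaker inhibitor, a lower number a stronger inhibitor.
Compound 2 `O=c1[nH]c(=O)n([C@@H]2O[C@@H]3COP(=O)(O)O[C@H]3[C@H]2O)cc1Cl` gives 278 ug/mL in this assay.
Compound 3 `O=c1[nH]c(=O)n([C@@H]2O[C@@H]3COP(=O)(O)O[C@H]3[C@H]2O)cc1F` gives 0.416 ug/mL in this assay.

Compound 3 stands lowest of the three measured numbers, and by a wide margin: an 860-fold lower number from compound 1 to compound 3 (2.94 log units; beyond the scatter) and a 670-fold lower number from compound 2 to compound 3 (2.82 log units; beyond the scatter). Compound 4 `O=c1[nH]c(=O)n([C@@H]2O[C@@H]3COP(=O)(O)O[C@H]3[C@H]2O)cc1Br` differs from compound 3 in one place: bromo in place of fluoro on an aromatic carbon. Within the data shown here, two measured steps bear on this change, the two just named, both large and both running toward the fluoro compound; the remaining step, a 1.3-fold lower number from compound 1 to compound 2 (0.11 log units; within the scatter), shows that the iodo and chloro compounds give numbers within the scatter of each other. Bromo is expected to behave like chloro and iodo rather than like fluoro, so a large rise in this assay is expected, a 720-fold higher number from compound 3 to compound 4 (2.86 log units; beyond the scatter). Compound 4 is therefore estimated at 300 ug/mL, with a range of 100 ug/mL to 700 ug/mL.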

Compound 4, concentration for 50% inhibition: 210 ug/mL
Beside the measured number, compound 4's estimate is 1.4-fold (0.15 log units) above it; the measured number falls inside the stated range.
By their numbers in this assay, from the lowest: compound 3; then compounds 4, 2 and 1 (each within the scatter of the next).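

In this assay bromo in place of fluoro gives a 500-fold higher number from compound 3 to compound 4 (2.70 log units; beyond the scatter) while bromo in place of chloro gives a 1.3-fold lower number from compound 2 to compound 4 (0.12 log units; within the scatter) and bromo in place of iodo gives a 1.7-fold lower number from compound 1 to compound 4 (0.23 log units; within the scatter). At this position, chloro, bromo and iodo therefore lie within the scatter of each other, and fluoro alone stands apart from all three. Nothing given here accounts for this gap.

The compounds shown leave open whether only fluoro gives such a low number. A plain hydrogen, a methyl, an amine or a nitrile on this carbon could show where other groups fall.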